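The source may hold more compounds than are shown below. What is called first, only, known or untested is meant among the compounds shown, and "the series" means these compounds.

In a functional assay on HeLa cells (Homo sapiens) for antiproliferative activity, read by CCK-8 assay, with a stated time of 72 h (a lower number here means a stronger inhibitor, a higher number a weaker inhibitor), compound 3 `Cc1cccc(C(=O)Nc2cccc(-c3oc4cc(-c5ccc(F)cc5)ccc4c(=O)c3O)c2)c1` gives 6650 nM. Compound 1 `O=C(Nc1cccc(-c2oc3cc(-c4ccc(F)cc4)ccc3c(=O)c2O)c1)c1ccc(F)cc1F` gives 10700 nM and compound 2 `Cc1ccccc1C(=O)Nc1cccc(-c2oc3cc(-c4ccc(F)cc4)ccc3c(=O)c2O)c1` gives 11900 nM in this assay; compound 3 has the smallest number of the three, but the steps of a 1.6-fold lower number from compound 1 to compound 3 (0.21 log units; within the scatter) and a 1.8-fold lower number from compound 2 to compound 3 (0.25 log units; within the scatter) both lie within the scatter, so the three cannot be told apart. Compound 4 `Cc1cc(C(=O)Nc2cccc(-c3oc4cc(-c5ccc(F)cc5)ccc4c(=O)c3O)c2)ccc1F` differs from compound 3 by fluoro in place of hydrogen on an aromatic carbon. Among the measured compounds shown here, none of the measured steps adds a fluoro to a methylphenyl; the nearest guide is a 1.1-fold higher number from compound 1 to compound 2 (0.05 log units; within the scatter), where fluorines on the amide aryl ring were exchanged for a methyl without a change beyond the scatter. Compound 4 is therefore expected to give about 6500 nM, between 3000 nM and 14000 nM, a step of a 1.0-fold lower number from compound 3 to compound 4 (0.01 log units; within the scatter) that is expected to stay within the scatter.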

Compound 4, half-maximal inhibitory concentration: 18900 nM
Compound 4: middle estimate off by 2.9-fold (0.46 log units), on the low side, and the stated range ends below it.
By their numbers in this assay, from the lowest: compounds 3, 1, 2 and 4 (each within the scatter of the next, the first and the last beyond it).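

In this assay, among the compounds shown here, fluoro in place of hydrogen on the aromatic carbon ortho to a methyl group and para to a large group gives a 2.8-fold higher number from compound 3 to compound 4 (0.45 log units; beyond the scatter), the first step beyond the scatter, so this one position on the 3-methylphenyl ring responds to a single added fluoro. Compound 4 stands apart only from compound 3, since a 1.6-fold higher number from compound 2 to compound 4 (0.20 log units; within the scatter) and a 1.8-fold higher number from compound 1 to compound 4 (0.25 log units; within the scatter) both stay within the scatter. Nothing available explains the step from hydrogen to fluoro.

As far as these compounds go, whether chloro, methoxy or an amine on this same carbon would give a similar step remains open. Also open, from the compounds shown here alone, is whether fluoro there gives the same step on a ring without the methyl group.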